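The compounds below may be only part of what the source reports. "The series", "measured", "known", "first", "only" and "open" are said of these compounds alone.

Measured compounds:
- compound 1 `COCOc1cc(/C=C/C(=O)OCC(=O)NN2CCOCC2)ccc1OCc1ccccc1`; in a functional assay on HeLa cells (Homo sapiens) for cytotoxicity, read by MTT assay, with a stated time of 72 h (on this read-out lower numbers stand for stronger inhibition and higher numbers for weaker inhibition), compound 1 gives only the limit > 200000 nM.
- compound 2 `COc1ccc(NC(=O)COC(=O)/C=C/c2cc(OC)c(OCc3ccc(Cl)c(Cl)c3)c(OC)c2)cc1`; in this assay compound 2 gives only the limit > 200000 nM.

Compound 2 stands at the limit of this assay, so no number is known for it, only that its inhibition did not reach the measurable range. Compound 1 sits at the same limit (the limit of > 200000 nM in this assay, at which 2 of the 2 values shown sit); the two values show nothing beyond that, and no comparison between them can be drawn.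

Compound 3 `COc1ccc(NC(=O)COC(=O)/C=C/c2cc(OC)c(OCc3ccccc3)c(OC)c2)cc1` has not yet been measured. It differs from compound 2 in one place: phenyl in place of 3,4-dichlorophenyl on a saturated chain carbon bound to an oxygen on an aromatic ring. For the measured compounds named here, no step between two measured compounds is available, so the size of this change cannot be read from data. Both values known in this assay sit at the limit, and compound 3 is expected to follow them, with no step beyond the usual scatter and a fair chance of another limit rather than a number. The step from compound 2 to compound 3 is expected to be a number no higher from compound 2 to compound 3 (the limit leaves the size open). Compound 3 is estimated at 200000 nM, with a range from 60000 nM to 600000 nM.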

Compound 3, half-maximal inhibitory concentration: > 200000 nM
Compound 3: no number, only a limit; the forecaster's own chance of this, stated with the estimate: 80%; the middle value lies on the limit itself.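

In this assay compound 3 gives > 200000 nM, which is a limit and not a number. No step can be read between compound 2 and compound 3, as both stand at the limit: the limit of > 200000 nM in this assay, at which 3 of the 3 values shown sit.

The compounds shown leave open how phenyl and 3,4-dichlorophenyl compare in this place, and where any of the three compounds would fall as a number.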